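The source may report more compounds than this note shows. Statements on the series, on what has been measured and on what is new or still open speak of the compounds shown alone.

Measured so far:
compound 1 `COc1ccc2c(-c3cc(C(F)(F)F)c(C#N)c(-c4cn(S(=O)(=O)c5ccc(C)cc5)c5cc(OC)ccc45)n3)cn(S(=O)(=O)c3ccc(C)cc3)c2c1` gives 26.7%
compound 2 `Cc1ccc(S(=O)(=O)n2cc(-c3cc(C(F)(F)F)cc(-c4cn(S(=O)(=O)c5ccc(C)cc5)c5ccccc45)n3)c3ccccc32)cc1` gives 36.7%

For the measured compounds named here, in a functional assay on A549 cells (Homo sapiens) for inhibition, tested at 1 uM (on this read-out higher numbers stand for a stronger effect at the one concentration tested and lower numbers for a weaker effect), compound 1 gives 26.7%; the only other number, from compound 2, is 36.7%, and the gap between the two lies within the scatter. Compound 3 `COc1ccc2c(-c3cc(C(F)(F)F)cc(-c4cn(S(=O)(=O)c5ccc(C)cc5)c5cc(OC)ccc45)n3)cn(S(=O)(=O)c3ccc(C)cc3)c2c1` has not yet been measured. It differs from compound 1 in one place: hydrogen in place of cyano on an aromatic carbon. Going by the values given here, no step between measured compounds is available to guide the expectation, so in this assay no shift beyond the scatter is expected in either direction. Compound 3 is therefore estimated at 30%, between 12% and 50%. The expected step is a number 3.3 percentage points higher from compound 1 to compound 3 (within the scatter).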

Compound 3, a percentage reported as inhibition, at one concentration (the size of the read-out at that concentration, not a potency): 35.5%
Beside the measured number, compound 3's estimate is 5.5 percentage points below it, within the range that was stated.
By their numbers in this assay, from the lowest: compounds 1, 3 and 2 (each within the scatter of the next).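

In this assay, for the compounds shown here, hydrogen in place of cyano gives a number 8.8 percentage points higher from compound 1 to compound 3 (within the scatter) and so supplies the first comparison at a single position. On this aromatic carbon, ortho to a trifluoromethyl group, the cyano group is therefore not needed to retain the read-out at the one concentration tested. Nothing available explains this result. Going by these compounds, it remains open whether an amine or a carboxylic acid on the same carbon would shift the number beyond the scatter.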